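Chloromethyl for Vinyl on the Amide Carbonyl

The source may report more compounds than this note shows. Statements on the series, on what has been measured and on what is new or still open speak of the compounds shown alone.

Measured so far:
- compound 1 `C=CC(=O)Nc1ccc(Cn2nc(-c3ccc(Oc4ccccc4)cc3)cc2C(=O)O)cc1`: > 60000 nM (a limit of the assay)
- compound 2 `O=C(CCl)Nc1ccc(Cn2nc(-c3ccc(Oc4ccccc4)cc3)cc2C(=O)O)cc1`: 4000 nM
- compound 3 `C=CC(=O)Nc1cccc(Cn2nc(-c3ccc(Oc4ccccc4)cc3)cc2CO)c1`: 1300 nM

In a functional assay on Rec1 cells (Homo sapiens) for inhibition, read by luminescence and CellTiter-Glo, with a stated time of 72 h (a lower number here means a stronger inhibitor, a higher number a weaker inhibitor), compound 1 gives only a limit, > 60000 nM. Compound 2 gives 4000 nM in this assay, a change of chloromethyl in place of vinyl on a carbonyl carbon that made an at least 15-fold lower number from compound 1 to compound 2 (1.17 log units; beyond the scatter). Compound 3 gives 1300 nM in this assay; the difference between the core of compound 3 and the core of compound 1 is not broken down here.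

Compound 4 `O=C(CCl)Nc1cccc(Cn2nc(-c3ccc(Oc4ccccc4)cc3)cc2CO)c1` carries the same change, (chloromethyl in place of vinyl on a carbonyl carbon), at a place described in the same words. The earlier step is known only as a bound because compound 1 sits at the limit of > 60000 nM in this assay, at which 1 of the 3 values shown sits, so its full size is open. A smaller step is expected here, a 4.3-fold lower number from compound 3 to compound 4 (0.64 log units; beyond the scatter), set beside the earlier one from compound 1 to compound 2. Compound 4 is therefore estimated at 300 nM, expected between 60 nM and 1500 nM.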

Compound 4, half-maximal inhibitory concentration: 400 nM
For compound 4 the middle estimate is 1.3-fold (0.12 log units) below the measured one; the measured number falls inside the stated range.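

Notes on the change: in this assay, chloromethyl in place of vinyl on a carbonyl carbon gives a 3.3-fold lower number from compound 3 to compound 4 (0.51 log units; beyond the scatter). The direction is shared by the two cores shown, but the size is not: the same change on two cores in this assay, an at least 15-fold lower number (1.17 log units; beyond the scatter) from compound 1 to compound 2 and a 3.3-fold lower number (0.51 log units; beyond the scatter) from compound 3 to compound 4, at least 4.6-fold (0.66 log units) apart, beyond the scatter of two such steps. The earlier step is only a bound, and the two cores differ in more than one place, so neither the full gap nor the part of the core that goes with it can be read: the limit of > 60000 nM in this assay, at which 1 of the 4 values shown sits.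

Open, as far as these compounds go, is whether the same direction holds on any core beyond these two. Also open, from the compounds shown here alone, is how a bromomethyl or a longer chloroethyl group on the same carbonyl carbon would compare with chloromethyl on the core of compound 4.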